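The source may hold more compounds than are shown below. What is called first, only, known or untested is meant among the compounds shown, and "the series" means these compounds.

Compound 1 (`COc1cc(/C=C/C(=O)/C=C/c2nc3c(C)c(C)ccc3n2C)ccc1O`) - 14100 nM
Compound 2 (`COc1ccc(/C=C/C(=O)/C=C/c2nc3ccccc3n2C)cc1O`) - 3600 nM
Compound 3 (`COc1ccc(/C=C/C(=O)/C=C/c2nc3c(C)cccc3n2C)cc1O`) - 7400 nM

In a functional assay on MCF7 cells (Homo sapiens) for cytotoxicity, read by MTT assay, with a stated time of 48 h (on this read-out higher numbers stand for weaker inhibition and lower numbers for stronger inhibition), compound 2 gives the lowest number of the three, at 3600 nM for now. The change to compound 4 (`COc1ccc(/C=C/C(=O)/C=C/c2nc3cc(O)ccc3n2C)cc1O`), still unmeasured, is hydroxy in place of hydrogen on an aromatic carbon and amounts to hydroxy in place of hydrogen on an aromatic carbon. For the measured compounds named here, the only measured single-place step is a 2.1-fold higher number from compound 2 to compound 3 (0.31 log units; beyond the scatter) with methyl in place of hydrogen on an aromatic carbon, and it is modest. That step involves a different group, so it bears only loosely on this change. Compared with compound 2, compound 1 reads higher at 14100 nM but differs in more than one place. Going by the values given here, no measured compound carries the hydroxy group at this place, so the direction remains uncertain. A modest rise in the number is expected, and the range also allows for no change. The expected step is a 1.4-fold higher number from compound 2 to compound 4 (0.14 log units; within the scatter) on this reading. In this assay the estimate for compound 4 is 5000 nM with an expected range from 1800 nM to 14000 nM as the likely span.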

Compound 4, half-maximal inhibitory concentration: 1900 nM
For compound 4 the middle estimate is 2.6-fold (0.42 log units) above the measured one; the measured number falls inside the stated range.
By their numbers in this assay, from the lowest: compounds 4 and 2 (each within the scatter of the next); then compounds 3 and 1 (each within the scatter of the next).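

Hydroxy in place of hydrogen on this aromatic carbon, meta to a fused ring and para to a fused ring, gives a 1.9-fold lower number from compound 2 to compound 4 (0.28 log units; within the scatter) in this assay, so compound 4 cannot be told apart from compound 2 on this read-out. For the compounds shown here, the earlier compounds offered only a methyl step at a different aromatic carbon, a 2.1-fold higher number from compound 2 to compound 3 (0.31 log units; beyond the scatter), so this is the first sign that the shared core can carry a substituent without a step beyond the scatter. Nothing available explains this outcome.

The compounds shown leave open whether an amine, a carboxylic acid or a fluorine atom on this same carbon would also stay within the scatter of compound 2. They also leave open whether hydroxy would read the same way on the other aromatic carbons of this ring.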